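Ethoxy to benzyloxy: working notes on compound 3

The source may hold more compounds than are shown below. What is called first, only, known or untested is meant among the compounds shown, and "the series" means these compounds.

Measured so far in a functional assay on CCRF-CEM cells (Homo sapiens) for cytotoxicity, with a stated time of 72 h; a higher number here means a weaker inhibitor, a lower number a stronger inhibitor:
Compound 1 `O=C(/C=C/C=C/C=C/c1ccc[nH]1)OCc1ccccc1`: 830 nM
Compound 2 `CCOC(=O)/C=C/C=C/C=C/C=C/c1[nH]ccc1Cl`: 270 nM

Of the two measured compounds, compound 2 has the lower number at 270 nM, and the gap to compound 1 lies beyond the scatter. Within the data shown here, with only two values, no trend can be claimed.

Compound 3 `O=C(/C=C/C=C/C=C/C=C/c1[nH]ccc1Cl)OCc1ccccc1` departs from compound 2 in one place: phenyl in place of methyl on a saturated chain carbon bound to an oxygen next to a carbonyl group. This is phenyl in place of methyl on a saturated chain carbon bound to an oxygen next to a carbonyl group, so ethoxy becomes benzyloxy.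

Among the measured compounds shown here, no measured pair isolates this change. Compound 1 also carries benzyloxy and gives 830 nM, but it differs from compound 2 elsewhere too, so that gap cannot be assigned to benzyloxy. The working expectation in this assay is therefore a small upward move or none, with no step beyond the scatter anticipated. The expected step is a 1.1-fold higher number from compound 2 to compound 3 (0.05 log units; within the scatter). For compound 3 the estimated value is 300 nM, with an expected range of 100 nM to 800 nM.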

Compound 3, half-maximal inhibitory concentration: 280 nM
Compound 3: middle estimate off by 1.1-fold (0.03 log units), on the high side, and the stated range covers the measured number.
By their numbers in this assay, from the lowest: compounds 2 and 3 (each within the scatter of the next); then compound 1.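

In this assay, the change from ethoxy to benzyloxy can now be read on its own: a 1.0-fold higher number from compound 2 to compound 3 (0.02 log units; within the scatter). On this saturated chain carbon bound to an oxygen next to a carbonyl group, phenyl in place of methyl, and with it a six-membered aromatic ring of carbon only, therefore leaves the number within the scatter. With benzyloxy common to both compounds, the other end of the structure gives a step that can be read, a 3.0-fold lower number from compound 1 to compound 3 (0.47 log units; beyond the scatter), for a chlorine-bearing group in place of a chlorine-free group on a double-bonded chain carbon bound to a double-bonded chain carbon, and nothing at hand accounts for either step.

Going by these compounds, that step does not separate the chlorine from the rest of the exchanged group, so their individual shares in the gap remain unknown. On these data alone, whether the flat result at the ester end extends beyond ethoxy and benzyloxy to a carboxylic acid or an amide also remains open.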